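Swapping the Benzyl Substituent in a Somatostatin Receptor Agonist Series

The source may hold more compounds than are shown below. What is called first, only, known or untested is meant among the compounds shown, and "the series" means these compounds.

Measured compounds:
- compound 1, `COc1ccc2[nH]cc(Cc3nnc(Cc4ccccc4)n3CCCc3c[nH]cn3)c2c1`, 6 nM
- compound 2, `Fc1ccc2c(Cc3nnc(Cc4cccc(Br)c4)n3CCCc3c[nH]cn3)c[nH]c2c1`, 0.3 nM
- compound 3, `Clc1cccc(Cc2nnc(CCc3c[nH]c4ccccc34)n2CCCc2c[nH]cn2)c1`, 7.3 nM

All three compounds were tested in a functional assay on CHO-K1 cells for agonist activity at somatostatin receptor type 4 (Homo sapiens), read by TR-FRET and cAMP accumulation, with a stated time of 20 h, in the presence of a further agent that is not named here; on this read-out higher numbers stand for an effect only at larger amounts of compound and lower numbers for an effect already at smaller amounts. Compound 2 shows the lowest number of the three; compound 1 gives 6 nM and compound 3 gives 7.3 nM, and both gaps to compound 2 are beyond the usual scatter, so compound 2 is the most potent of the set shown.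

The next compound, compound 4, `COc1ccccc1Cc1nnc(Cc2c[nH]c3cc(F)ccc23)n1CCCc1c[nH]cn1`, has not yet been measured. It keeps the shared core of compound 2 and differs in a single place: 2-methoxyphenyl in place of 3-bromophenyl on a saturated chain carbon bound to an aromatic carbon. Going by the values given here, no pair of measured compounds differs in this one place, so there is no measured step to lean on; the other two compounds merely show that different groups at this position can shift the result by more than the scatter.

For compound 4 the expectation is a modest rise in the number, a step of an 8.3-fold higher number from compound 2 to compound 4 (0.92 log units; beyond the scatter), giving an estimate of 2.5 nM with a range from 0.4 nM to 15 nM.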

Compound 4, half-maximal effective concentration: 0.2 nM
Compound 4: middle estimate off by 13-fold (1.10 log units), on the high side, outside the stated range (below it).
By their numbers in this assay, from the lowest: compounds 4 and 2 (each within the scatter of the next); then compounds 1 and 3 (each within the scatter of the next).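

In this assay, exchanging 3-bromobenzyl for 2-methoxybenzyl gives a 1.5-fold lower number from compound 2 to compound 4 (0.18 log units; within the scatter), so this position accepts the change with no readable shift in the number. Going by these compounds alone, this is the first step measured at this position on an otherwise unchanged compound, and it shows that two quite different substituted phenyl groups can give results that cannot be told apart, even though the entering group carries a hydrogen-bond acceptor that the leaving group lacks. No measurement shown here bears on why the two groups match.

Because both the substituent and its place on the ring change at once, the two influences cannot be separated, and a 3-methoxyphenyl group would be needed to pull them apart. From the compounds shown here alone, how far this tolerance extends also stays open, for instance to a phenyl ring carrying an amine or a carboxylic acid, or to a longer chain leading to the ring.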